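A few compounds are considered here, and "the series" means these few. Any claim that something is new, unique, unknown or untested is made for them only; others in the source may bear on it.

Working notes on the series. Of the compounds shown here, two have numbers so far. Compound 1 `Cn1cc(-c2n[nH]c3cc(-c4ccccc4)ccc23)cn1` gives 12300 nM in an assay on isolated protein for inhibition of tyrosine-protein kinase receptor UFO (Homo sapiens), with a stated time of 1.5 h; a lower number here means a stronger inhibitor, a higher number a weaker inhibitor. Compound 2 `FC(F)(F)c1cccc2[nH]ncc12` gives 184000 nM in this assay. Compound 1 stands lowest of the two numbers; its nearest neighbour is compound 2, whose number lies beyond the scatter above it. Within the data shown here, no pair of measured compounds differs in only one place, so no single step is laid out between them; the two values show only that compound 1 sits well below compound 2.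

The step now followed runs from compound 1 to compound 3 `Cn1cc(-c2n[nH]c3cc(Br)ccc23)cn1`, which is to be measured in this assay. The change is bromo in place of phenyl on an aromatic carbon. The phenyl of compound 1 is thus replaced by a single bromine atom at the same position on the core. With no measured step of this kind in hand, the expectation is a rise in the number from compound 1 to compound 3, most likely of moderate size and beyond the scatter, since the large aromatic group is lost and compound 2, which carries only a small substituent on a related core, gives 184000 nM. For compound 3 the estimate in this assay is 40000 nM, with a range from 12000 nM to 150000 nM, meaning an expected step of a 3.3-fold higher number from compound 1 to compound 3 (0.51 log units; beyond the scatter).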

Compound 3, half-maximal inhibitory concentration: 950 nM
Compound 3: middle estimate off by 42-fold (1.62 log units), on the high side, and the stated range ends above it.
By their numbers in this assay, from the lowest: compound 3; then compound 1; then compound 2.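

At this position, on an aromatic carbon of the shared core, the phenyl of compound 1 is not required for activity in this assay. Bromo in place of phenyl gives a 13-fold lower number from compound 1 to compound 3 (1.11 log units; beyond the scatter) and compound 3 reaches 950 nM with a single bromine atom where a six-carbon aromatic ring stood, so a large aromatic group here gives a higher number than this one heavy atom. Nothing at hand accounts for the size of this step, which so far rests on this one pair.

As far as these compounds go, whether bromo itself matters or any small substituent would serve remains open, and chloro, methyl, an amine or a carboxylic acid on the same aromatic carbon, or simple hydrogen there, would separate these readings. Among these compounds, also open is whether the step from phenyl to bromo keeps its size when another part of the core of compound 1 is changed, since only one pair of compounds differing at this position is in hand.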